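The source may report more compounds than this note shows. Statements on the series, on what has been measured and on what is new or still open speak of the compounds shown alone.

Working notes on the series.

Of the compounds shown here, three in a physicochemical assay for acid dissociation, have numbers so far. Compound 1 `COc1ccc(F)cc1CNCCCNc1ccnc2cc(CCc3ccccc3)ccc12` gives 9.47; compound 2 `COc1ccc(F)cc1CNCCCNc1ccnc2cc(Cc3ccc(F)cc3Cl)ccc12` gives 9.47; compound 3 `COc1ccc(F)cc1CNCCCNc1ccnc2cc(Oc3cccc(N(C)C)c3)ccc12` gives 9.28. Compound 3 holds the lowest of the three numbers, but its gap to compound 1 and to compound 2 is within the scatter, so no order can be read among them. Within the data shown here, the steps so far are no change at the digits printed from compound 1 to compound 2 (within the scatter), a number 0.19 log units lower from compound 1 to compound 3 (within the scatter) and a number 0.19 log units lower from compound 2 to compound 3 (within the scatter), each within the scatter.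

Compound 4 `COc1ccc(F)cc1CNCCCNc1ccnc2cc(Oc3ccccc3)ccc12` is not yet measured. Its difference from compound 3 is hydrogen in place of dimethylamino on an aromatic carbon; it lies on an aromatic carbon of a six-membered aromatic ring of carbon only, meta to a large group, and cut one bond further out reads 3-(dimethylamino)phenoxy to phenoxy. Among the measured compounds shown here, the three measured steps all alter the same side of the shared core and none moved the number beyond the scatter; they are the only comparisons that bear here. The step in this assay from compound 3 to compound 4 is therefore expected to be a number 0.10 log units higher from compound 3 to compound 4 (within the scatter), none beyond the scatter. Compound 4 is estimated at 9.38, with a range from 9.05 to 9.7.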

Compound 4, acid dissociation constant: 9.28
Estimate against measurement, compound 4: 0.10 log units above; the range from low to high includes it.
By their numbers in this assay, from the lowest: compounds 3, 4, 1 and 2 (each within the scatter of the next).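

Taking dimethylamino off the outer ring gives no change at the digits printed from compound 3 to compound 4 (within the scatter) in this assay and is the first step here confined to a single substituent, on an aromatic carbon of a six-membered aromatic ring of carbon only, meta to a large group. The unsubstituted phenoxy also stands within the scatter of the two carbon-linked groups, with a number 0.19 log units lower from compound 2 to compound 4 (within the scatter) and with a number 0.19 log units lower from compound 1 to compound 4 (within the scatter) so that no order can be read among the four compounds. Nothing available bears on why these values lie so close together.

Going by these compounds, whether a carboxylic acid or a primary amine at this same place would give a step beyond the scatter remains open. So does the effect of a longer chain in place of the propyl chain of the shared core, which all four compounds carry unaltered.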